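A chloropyridine in place of a dimethoxyphenyl

This account rests on a few compounds, and the source may have more. Where it says the series, first, only, none or still open, it means among the compounds named here.

Values in a functional assay on HeLa cells (Homo sapiens) for cytotoxicity, read by MTT assay, with a stated time of 48 h; on this read-out higher numbers stand for weaker inhibition and lower numbers for stronger inhibition:
- compound 1 `CC1(C)CCC[C@]2(C)[C@@H](CC[C@@](C)(O)/C=C/c3ccccc3)[C@](C)(O)CC[C@@H]12`: 3320 nM
- compound 2 `CC1(C)CCC[C@]2(C)[C@@H](CC[C@@](C)(O)/C=C/c3cncc4ccccc34)[C@](C)(O)CC[C@@H]12`: 46000 nM
- compound 3 `COc1cccc(OC)c1/C=C/[C@](C)(O)CC[C@@H]1[C@@]2(C)CCCC(C)(C)[C@@H]2CC[C@@]1(C)O`: 48200 nM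

Compound 3 stands at the high, weak end of this small set, and the data show a 1.0-fold higher number from compound 2 to compound 3 (0.02 log units; within the scatter). Compound 4 `CC1(C)CCC[C@]2(C)[C@@H](CC[C@@](C)(O)/C=C/c3ccc(Cl)nc3)[C@](C)(O)CC[C@@H]12` keeps the shared core and changes only the ring group on the chain: 6-chloropyridin-3-yl in place of 2,6-dimethoxyphenyl on a double-bonded chain carbon bound to a double-bonded chain carbon. For the measured compounds named here, two measured steps bear on this, since both replaced the plain phenyl: a 14-fold higher number from compound 1 to compound 2 (1.14 log units; beyond the scatter) and a 15-fold higher number from compound 1 to compound 3 (1.16 log units; beyond the scatter). Neither of them tested the entering group, so the guide is loose. A ring group other than phenyl has so far kept the number high, so only a modest fall is expected. The estimated step is a 2.4-fold lower number from compound 3 to compound 4 (0.38 log units; beyond the scatter). For compound 4 the expected value in this assay is 20000 nM, with an estimated range of 6000 nM to 60000 nM.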

Compound 4, half-maximal inhibitory concentration: 3680 nM
Beside the measured number, compound 4's estimate is 5.4-fold (0.74 log units) above it, and the stated range ends above it.
By their numbers in this assay, from the lowest: compounds 1 and 4 (each within the scatter of the next); then compounds 2 and 3 (each within the scatter of the next).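

In this assay, a ring other than phenyl at this chain carbon need not push the number up. 6-Chloropyridin-3-yl gives a far lower number than 2,6-dimethoxyphenyl (a 13-fold lower number from compound 3 to compound 4 (1.12 log units; beyond the scatter)) and isoquinolin-4-yl (a 13-fold lower number from compound 2 to compound 4 (1.10 log units; beyond the scatter)), and it stands level with plain phenyl (a 1.1-fold higher number from compound 1 to compound 4 (0.04 log units; within the scatter)). Nothing shown explains why these rings differ.

Going by these compounds, whether the chlorine or the ring nitrogen matters more stays open. A pyridin-3-yl without chlorine, or a chlorophenyl, would separate the two.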